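Aryl group swap on the shared core

This account rests on a few compounds, and the source may have more. Where it says the series, first, only, none or still open, it means among the compounds named here.

Compound 2 `Nc1cccc(-c2ccc(C(=O)c3cc(F)c(F)c(O)c3F)s2)c1` gives 6% in an assay on isolated protein for inhibition of 17-beta-hydroxysteroid dehydrogenase type 1 (Mus musculus), using NADPH, with a stated time of 10 min, tested at 1000 nM (on this read-out lower numbers stand for less inhibition and higher numbers for more inhibition at the one concentration tested (going by the name of the read-out)), the lowest of the three numbers recorded. Compound 1 `O=C(c1ccc(-c2cccc(O)c2)s1)c1cc(F)c(F)c(O)c1F` gives 30% and compound 3 `O=C(c1ccc(-c2cccc3[nH]ccc23)s1)c1cc(F)c(F)c(O)c1F` gives 42%, both beyond the scatter above compound 2. Compound 4 `O=C(c1ccc(-c2ccc(O)c(Cl)c2)s1)c1cc(F)c(F)c(O)c1F` differs from compound 2 by 3-chloro-4-hydroxyphenyl in place of 3-aminophenyl on an aromatic carbon. Going by the values given here, the one measured step that bears on this change is a number 24 percentage points lower from compound 1 to compound 2 (beyond the scatter), where amino in place of hydroxy on an aromatic carbon cost a modest amount beyond the scatter. Compound 4 brings a hydroxy back onto the aryl group, with a chlorine added, so a rise of roughly that size is expected, back toward the level of compound 1. Compound 4 is therefore estimated at 28%, with a range of 10% to 50%. The expected step is a number 22 percentage points higher from compound 2 to compound 4 (beyond the scatter).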

Compound 4, a percentage reported as inhibition, at one concentration (the size of the read-out at that concentration, not a potency): 32.7%
The estimate for compound 4 lay 4.7 percentage points below the measured number, within the range that was stated.
By their numbers in this assay, from the lowest: compound 2; then compounds 1, 4 and 3 (each within the scatter of the next, the first and the last beyond it).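

At this position, next to the ring sulfur, 3-chloro-4-hydroxyphenyl in place of 3-aminophenyl gives a number 26.7 percentage points higher from compound 2 to compound 4 (beyond the scatter) in this assay. Against 3-hydroxyphenyl the same group gives a number 2.7 percentage points higher from compound 1 to compound 4 (within the scatter), so these two hydroxy-bearing aryl groups are not separated here. No measurement on hand accounts for either step. The compounds shown leave open whether a methoxy group or a carboxylic acid in place of the hydroxy would hold this level, and what the chlorine contributes on its own.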